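Pyrazoline series: acyl variation on the ring nitrogen

This account rests on a few compounds, and the source may have more. Where it says the series, first, only, none or still open, it means among the compounds named here.

Measured so far:
compound 1 `CC1=NN(C(=O)/C=C/c2ccccc2)C(c2ccccc2O)C1` — 39600 nM
compound 2 `COc1ccccc1C1CC(C)=NN1C(=O)CN1CCC(OC)CC1` — 9550 nM
compound 3 `O=C(c1ccccc1Cl)N1N=C(c2cc3ccccc3oc2=O)CC1c1ccccc1` — 6640 nM

All three values come from a functional assay on MGC-803 cells (Homo sapiens) for cytotoxicity, read by MTT assay, with a stated time of 48 h; a higher number here means a weaker inhibitor, a lower number a stronger inhibitor. Compound 3 holds the lowest of the three numbers. Its gap to compound 2 lies within the scatter, so no order between these two can be read; its gap to compound 1 lies beyond the scatter, and compound 1 stands as the clearly weaker of that pair.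

Compound 4 `CC1CCCCN1CC(=O)N1N=C(c2cc3ccccc3oc2=O)CC1c1ccccc1` is not yet measured. Compared with compound 3 the change is (2-methylpiperidin-1-yl)methyl in place of 2-chlorophenyl on a carbonyl carbon. The shared core of compound 3 is retained; only the group on the carbonyl carbon is exchanged.

Within the data shown here, no step between measured compounds isolates an acyl change of this sort, so the expectation rests on the spread of the three values. Compound 2 gives 9550 nM and shows that a carbonyl bearing a saturated nitrogen ring can sit in the same range as compound 3. The step of a 1.3-fold lower number from compound 3 to compound 4 (0.12 log units; within the scatter) is therefore expected to be small, at most a modest move toward a lower number and possibly none beyond the scatter. For compound 4 the estimate is 5000 nM, with a range from 1500 nM to 16000 nM.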

Compound 4, half-maximal inhibitory concentration: "not active" (no number reported)
No number was reported for compound 4, and the estimate cannot be compared.
By their numbers in this assay, from the lowest: compounds 3 and 2 (each within the scatter of the next); then compound 1.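

Among these compounds, compound 4 is reported as not active in this assay, with no number, so no step from compound 3 to compound 4 can be read. The compounds shown leave open how far compound 4 lies from compound 3, and how other groups on the carbonyl carbon would read on this core. No available evidence bears on this result.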